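The source may hold more compounds than are shown below. What is called first, only, known or untested is meant among the compounds shown, and "the series" means these compounds.

In a functional assay on cells (leukaemia cell line, Homo sapiens) for inhibition, read by sulforhodamine B assay, with a stated time of 48 h (a lower number here means that less compound is tolerated, a higher number that more compound is tolerated), compound 1 (`O=S(=O)(Nc1ccc(F)cc1F)c1ccc(-c2cnc(C3CC3)o2)cc1`) gives > 100000 nM, which is a limit of the assay and not a number. Compound 2 (`Cc1ccc(Cl)c(NS(=O)(=O)c2ccc(-c3cnc(C4CC4)o3)cc2)c1`) gives > 100000 nM, also a limit and not a number, so its place in the series cannot be fixed more closely. The measured evidence consists of the limit of > 100000 nM in this assay, at which 2 of the 2 values shown sit. Among the measured compounds shown here, the single measured step, a step that the two limits leave unreadable from compound 1 to compound 2, therefore has no readable size. Compound 3 (`O=S(=O)(Nc1ccc(I)c(Cl)c1)c1ccc(-c2cnc(C3CC3)o2)cc1`) carries 3-chloro-4-iodophenyl in place of 2-chloro-5-methylphenyl on a sulfonamide nitrogen. The same group position has already been changed once in the step to compound 2 (a step that the two limits leave unreadable from compound 1 to compound 2) without a number emerging, so a further change there is expected to leave compound 3 at the limit as well. No step beyond the usual scatter is expected in this assay, though if a number does appear, it would be expected to lie lower. The expected step is a number no higher from compound 2 to compound 3 (the limit leaves the size open). For compound 3 the estimated value is 100000 nM, with an expected range from 30000 nM to 100000 nM.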

Compound 3, concentration lethal to 50% of the cells: > 100000 nM
Compound 3 ended at the assay's limit; the forecaster's own chance of this, stated with the estimate: 85%; the middle value lies on the limit itself.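

Compound 3 stays at the assay's limit, as do compound 1 and compound 2, so neither new step, to compound 3 from compound 2 or from compound 1, can be read. The compounds shown leave open whether any group on a sulfonamide nitrogen would give a readable number in this assay, and how far apart these three compounds lie: the limit of > 100000 nM in this assay, at which 3 of the 3 values shown sit.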